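A few compounds are considered here, and "the series" means these few. Any claim that something is new, unique, unknown or untested is made for them only; others in the source may bear on it.

Measured compounds:
compound 1 `Oc1ccccc1C(O)(c1ccccc1)c1ccccc1`: 800 nM; 3300 nM (2 entries)
compound 2 `OC(c1ccccc1)(c1ccccc1)c1ccc(C(F)(F)F)cc1`: 3100 nM

In a functional assay on NIH3T3 cells (Mus musculus) for antiproliferative activity (on this read-out lower numbers stand for stronger inhibition and higher numbers for weaker inhibition), compound 1 gives 800 nM; 3300 nM (2 entries), and the several entries of compound 1 in this assay, 800 nM; 3300 nM (2 entries) shows that repeated measurements of the same compound can spread considerably. In this assay, within the data shown here, compound 2 gives 3100 nM; this is the only number available for compound 2 in that assay, with one further measurement that produced no single number. Compound 2 thus sits in the same general region as compound 1, and nothing in these two values separates them.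

Compound 3 `OC(c1ccccc1)(c1ccccc1)c1ccc(Cl)cc1` has not yet been measured in this assay. It differs from compound 2 in one place: chloro in place of trifluoromethyl on an aromatic carbon. Among the measured compounds shown here, no measured pair shows what this exchange does here, so the expectation can rest only on compound 2 itself and on the size of the change. One small group is swapped for another on the same aromatic carbon, and the step from compound 2 to compound 3 is expected to be small, not beyond the usual scatter, in either direction. Compound 3 is therefore expected to give about 3000 nM in this assay, within a range of 1000 nM to 9000 nM, which corresponds to an expected step of a 1.0-fold lower number from compound 2 to compound 3 (0.01 log units; within the scatter).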

Compound 3, half-maximal inhibitory concentration: 800 nM
The estimate for compound 3 lay 3.8-fold (0.57 log units) above the measured number; the whole stated range lies above it.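

The exchange of trifluoromethyl for chloro, on the aromatic carbon para to a large group, now has a measured effect in this assay, and the step is a 3.9-fold lower number from compound 2 to compound 3 (0.59 log units; beyond the scatter). Among these compounds, the earlier compounds offered no pair differing in one place, so this is the first sign that the number responds to what sits at this position, and here the group with fewer heavy atoms goes with the stronger inhibition. The step is printed as beyond the usual scatter, yet it rests on a single pair and is about as wide as the spread that repeated testing gave for one compound: the several entries of compound 1 in this assay, 800 nM; 3300 nM (2 entries)

Going by these compounds, what remains open is why the number falls, since this one pair gives a direction and no reason, and it cannot show whether the gain comes from chloro itself or from the absence of trifluoromethyl. It is also unknown how far this position reaches, for instance whether an amine, a carboxylic acid or a longer chain such as propyl on the same aromatic carbon would push the number lower still or back up.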